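The compounds below may be only part of what the source reports. "The series", "measured", "known", "first", "only" and "open" are said of these compounds alone.

- Compound 1 `N[C@H]1CC[C@H](Nc2c(C(=O)NCc3ccc(Oc4ccccc4)cc3)nc(Br)c3cccnc23)CC1`: "not determined" (no result reported)
- Compound 2 `COc1cccc(CNC(=O)c2nc(Br)c3cccnc3c2N[C@H]2CC[C@H](N)CC2)c1`: 6000 nM
- Compound 3 `N[C@H]1CC[C@H](Nc2c(C(=O)NCc3ccc(F)cc3)nc(N3CCCCC3)c3cccnc23)CC1`: > 10000 nM

These results come from a functional assay on SK-BR-3 cells (Homo sapiens) for cytotoxicity, read by MTT assay, with a stated time of 72 h; a higher number here means a weaker inhibitor, a lower number a stronger inhibitor. Going by the values given here, compound 2 holds the only exact number in this small set, so it is the sole numerical reference point. Compound 3 shows > 10000 nM, which is a limit of the assay and not an exact number. Compound 1 has no reported result.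

The next compound to be tested is compound 4 `COc1ccc(CNC(=O)c2nc(Br)c3cccnc3c2N[C@H]2CC[C@H](N)CC2)cc1`. It differs from compound 2 in one place: 4-methoxyphenyl in place of 3-methoxyphenyl on a saturated chain carbon bound to an amide-type nitrogen. In words, 4-methoxyphenyl stands in place of 3-methoxyphenyl on a saturated chain carbon bound to an amide-type nitrogen. The two compounds have the same atoms, joined differently.

Among the compounds with values here, no measured pair here shows what this kind of change does in this assay. The expectation is therefore no step beyond the usual scatter, in either direction, from the 6000 nM of compound 2. The estimated change is no change at the digits printed from compound 2 to compound 4 (within the scatter). For compound 4, the estimated value is 6000 nM, with an expected range of 2500 nM to 10000 nM.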

Compound 4, half-maximal inhibitory concentration: 5000 nM
Beside the measured number, compound 4's estimate is 1.2-fold (0.08 log units) above it; low and high end bracket the measured number.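

In this assay, going by these compounds alone, the swap of 3-methoxyphenyl for 4-methoxyphenyl on a saturated chain carbon bound to an amide-type nitrogen gives the first measured pair at this place, with a step of a 1.2-fold lower number from compound 2 to compound 4 (0.08 log units; within the scatter). The two compounds have the same atoms, joined differently, and this rearrangement does not separate them in this assay. Within the data shown here, compound 3 remains a limit and not a number, so it adds no step at this place: the limit of > 10000 nM in this assay, at which 1 of the 4 values shown sits.

This single pair speaks only for these two methoxyphenyl groups, and compound 1, with no reported result, adds nothing to it. As far as these compounds go, how a carboxylic acid or an amine on this phenyl ring, or a longer chain in place of the benzyl link, would read in this assay stays open.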